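This account rests on a few compounds, and the source may have more. Where it says the series, first, only, none or still open, it means among the compounds named here.

Series notes. Compound 1 `O=C(NNC(=O)c1cc([N+](=O)[O-])c[nH]1)Nc1ccc(Br)cc1`, compound 2 `O=C(NNC(=S)Nc1ccc([N+](=O)[O-])cc1)c1cc([N+](=O)[O-])c[nH]1` and compound 3 `Cn1cc([N+](=O)[O-])cc1C(=O)NNC(=S)NC1CCCCC1` have been run in an ADME assay on Vero cells (Chlorocebus sabaeus) for cytotoxicity, read by MTT assay, with a stated time of 72 h; on this read-out higher numbers stand for weaker inhibition and lower numbers for stronger inhibition. Compound 1 gives 378000 nM, compound 2 gives 529000 nM and compound 3 gives 352000 nM. Compound 1 stands second highest of the three, with compound 3 nearest and compound 2 furthest, both within the scatter, so the three numbers show no separation. For the measured compounds named here, no pair differing in one place has been measured. Compound 4 `O=C(NNC(=O)c1cc([N+](=O)[O-])c[nH]1)Nc1ccc(Cl)cc1` differs from compound 1 by chloro in place of bromo on an aromatic carbon; cut one bond further out, 4-bromophenyl becomes 4-chlorophenyl. In this assay no step beyond the scatter is expected for this change. Compound 4 is estimated at 380000 nM, within 190000 nM to 760000 nM. The expected step is a 1.0-fold higher number from compound 1 to compound 4 (0.00 log units; within the scatter).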

Compound 4, half-maximal inhibitory concentration: 218000 nM
Compound 4: middle estimate off by 1.7-fold (0.24 log units), on the high side; low and high end bracket the measured number.
By their numbers in this assay, from the lowest: compounds 4, 3, 1 and 2 (each within the scatter of the next, the first and the last beyond it).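

The first pair differing in one place gives, in this assay, a 1.7-fold lower number from compound 1 to compound 4 (0.24 log units; within the scatter), so chloro and bromo on this aromatic carbon, para to a large group, are not told apart. Exchanging one halogen for the other at this position therefore gives no step beyond the scatter. No measurement at hand bears on what lies behind this result.

Going by these compounds, whether an amine, a carboxylic acid or a longer chain on this aromatic carbon would give a step beyond the scatter stays open. On these data alone, whether the same exchange behaves alike on the cores of compound 2 or compound 3 also stays open.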